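Swapping trifluoromethoxy for trifluoromethyl on a salicylanilide

The source may hold more compounds than are shown below. What is called first, only, known or untested is meant among the compounds shown, and "the series" means these compounds.

Measured so far:
compound 1 `O=C(Nc1cccc(C(F)(F)F)c1)c1cc(F)ccc1O` gives 1010 nM in a functional assay on KG-1 cells (Homo sapiens) for cytotoxicity, read by luminescence and CellTiter-Glo, with a stated time of 3 days; on this read-out higher numbers stand for weaker inhibition and lower numbers for stronger inhibition
compound 2 `O=C(Nc1ccc(OC(F)(F)F)c(Cl)c1)c1cc(Cl)ccc1O` gives 460 nM in this assay
compound 3 `O=C(Nc1cccc(OC(F)(F)F)c1)c1cc(F)ccc1O` gives 830 nM in this assay

Compound 2 has the lowest of the three numbers, yet its gap to compound 3 lies within the usual scatter. How the cores of compound 2 and compound 3 differ is not broken down here.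

Compound 4 `O=C(Nc1ccc(C(F)(F)F)c(Cl)c1)c1cc(Cl)ccc1O` has not yet been measured. It differs from compound 2 by trifluoromethyl in place of trifluoromethoxy on an aromatic carbon. The same kind of change links compound 3 to compound 1, (trifluoromethyl in place of trifluoromethoxy on an aromatic carbon); the surroundings differ, as the group in compound 4 sits ortho to a chloro group and para to a large group, whereas in compound 1 it sits meta to a large group. That earlier step was a 1.2-fold higher number from compound 3 to compound 1 (0.09 log units; within the scatter). On that basis a step of similar size is expected in this assay: a 1.1-fold higher number from compound 2 to compound 4 (0.04 log units; within the scatter). Compound 4 is therefore estimated at 500 nM, likely between 250 nM and 1000 nM.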

Compound 4, half-maximal inhibitory concentration: 450 nM
For compound 4 the middle estimate is 1.1-fold (0.05 log units) above the measured one, within the range that was stated.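

In this assay, trifluoromethyl in place of trifluoromethoxy gives a 1.0-fold lower number from compound 2 to compound 4 (0.01 log units; within the scatter), so on this core the two groups cannot be told apart. The same change on the other core gives a matching picture, and the two steps do not differ: the same change on two cores in this assay, a 1.2-fold higher number (0.09 log units; within the scatter) from compound 3 to compound 1 and a 1.0-fold lower number (0.01 log units; within the scatter) from compound 2 to compound 4, 1.2-fold (0.09 log units) apart, within the scatter of two such steps. So the change carried over between these two cores in this assay, but two pairs set no rule for other cores and do not explain why the numbers hold steady.

As far as these compounds go, it remains open whether a nitrile or an amine on that aromatic carbon would also leave the number in place. From the compounds shown here alone, it is equally open whether the match would hold on a core carrying a carboxylic acid.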